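Closing a Terminal Alkene into a Cyclohexyl Ring

This account rests on a few compounds, and the source may have more. Where it says the series, first, only, none or still open, it means among the compounds named here.

Compound 1 `C=CCCCCCCCS(=O)(=O)/C=C/c1ccc(O)c(O)c1`: 6900 nM in a functional assay, read by fluorescence and spectrophotometry, with a stated time of 1 h; a lower number here means that less compound is needed, a higher number that more compound is needed for the effect
Compound 2 `CCCCCCCS(=O)(=O)/C=C/c1ccc(O)c(O)c1`: 7100 nM in this assay

Within the data shown here, compound 1 stands together with compound 2: the only measured step, a 1.0-fold higher number from compound 1 to compound 2 (0.01 log units; within the scatter), removes the vinyl end of the chain and leaves the number within the scatter. Compound 3 `O=S(=O)(/C=C/c1ccc(O)c(O)c1)CCCC1CCCCC1` carries cyclohexyl in place of hex-5-en-1-yl on a saturated chain carbon, three bonds along the chain from a sulfonyl sulfur. Among the measured compounds shown here, no measured step bears on a ring in this place; the single step touches the far end of the chain and was flat, so the step is expected to be small, a 1.0-fold higher number from compound 1 to compound 3 (0.01 log units; within the scatter). Compound 3 is therefore estimated at 7000 nM, with a range from 3000 nM to 16000 nM.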

Compound 3, half-maximal effective concentration: 7900 nM
Estimate against measurement, compound 3: 1.1-fold (0.05 log units) below; the range from low to high includes it.
By their numbers in this assay, from the lowest: compounds 1, 2 and 3 (each within the scatter of the next).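

Joining the same atoms into a cyclohexyl ring in place of the open hex-5-en-1-yl end stays within the scatter in this assay (a 1.1-fold higher number from compound 1 to compound 3 (0.06 log units; within the scatter)). Cyclohexyl in place of butyl also stays within the scatter (a 1.1-fold higher number from compound 2 to compound 3 (0.05 log units; within the scatter)). At this place, three bonds along the chain from a sulfonyl sulfur, a ring and both open chains therefore read alike. No evidence is available to explain this result. As far as these compounds go, whether an amine, a carboxylic acid or a longer chain at this place would read differently remains open.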